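Stereo pair in the carbamate series: compound 1 to compound 3

The source may hold more compounds than are shown below. What is called first, only, known or untested is meant among the compounds shown, and "the series" means these compounds.

Measured so far:
compound 1 `C=C1C(=O)OC[C@@H]1CCOC(=O)Nc1cc(C)cc(C)c1`, 13600 nM
compound 2 `C=C1C(=O)OC[C@H]1CCOC(=O)Nc1cccc(Br)c1`, 21800 nM

Compound 1 `C=C1C(=O)OC[C@@H]1CCOC(=O)Nc1cc(C)cc(C)c1` gives 13600 nM in an ADME assay on RAW264.7 cells (Mus musculus) for cytotoxicity, read by MTT assay, with a stated time of 18 h (on this read-out higher numbers stand for lower toxicity in this test and lower numbers for higher toxicity in this test), the lower of the two numbers in hand. Compound 2 `C=C1C(=O)OC[C@H]1CCOC(=O)Nc1cccc(Br)c1` gives 21800 nM in this assay; the gap between compound 1 and compound 2 falls within the usual scatter, so the two read as the same on this assay. Within the data shown here, no pair of measured compounds differs in a single place, so no step size is known.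

Compound 3 `C=C1C(=O)OC[C@H]1CCOC(=O)Nc1cc(C)cc(C)c1` differs from compound 1 as follows: the two compounds have the same atoms and bonds and differ only in configuration as drawn: 1 of 1 stereo elements differ; a stereocentre at a saturated ring carbon is drawn R in compound 1 and S in compound 3. The two compounds have the same atoms and bonds and differ only in configuration as drawn, at a stereocentre at a saturated ring carbon. Nothing measured here indicates how this assay responds to configuration alone. The expectation is therefore no step beyond the scatter, in either direction, from compound 1 to compound 3: a 1.1-fold higher number from compound 1 to compound 3 (0.04 log units; within the scatter). Compound 3 is expected to give 15000 nM, within 7000 nM to 32000 nM.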

Compound 3, half-maximal cytotoxic concentration: 12700 nM
Estimate against measurement, compound 3: 1.2-fold (0.07 log units) above; the measured number falls inside the stated range.
By their numbers in this assay, from the lowest: compounds 3, 1 and 2 (each within the scatter of the next).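

In this assay, changing the stereocentre at the saturated ring carbon from R to S gives a 1.1-fold lower number from compound 1 to compound 3 (0.03 log units; within the scatter), so the two configurations read as the same. Among these compounds, this is the first measured step, and it shows that, with this substitution on the carbamate, the configuration at this position produces no separation beyond the scatter in this test. The step can be assigned to configuration alone because nothing else changes: the fact that compounds 1 and 3 differ only in the configuration as drawn

One pair cannot show whether configuration at this carbon remains equally silent when the substituents on the aromatic ring change, as in the bromine-bearing compound 2. Also open, from the compounds shown here alone, is how the read-out responds when the carbamate gives way to an amide, or when a longer chain links it to the shared core.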